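The compounds below may be only part of what the source reports. "The series", "measured", "known", "first", "only" and "open" are said of these compounds alone.

Of the compounds shown here, two have been measured so far, and a third awaits its number. Compound 1 `Oc1cccc(-c2cc(-c3cccc(F)c3)cc(-c3cccc(O)c3)n2)c1` carries two 3-hydroxyphenyl groups and a 3-fluorophenyl group on its shared core. In a functional assay on HCT-15 cells (Homo sapiens) for inhibition (on this read-out lower numbers stand for stronger inhibition and higher numbers for weaker inhibition), compound 1 gives 7860 nM. Compound 2 `Oc1ccc(-c2cc(-c3cccc(F)c3)cc(-c3cccc(O)c3)n2)cc1` differs only in that one hydroxyphenyl group is a 4-hydroxyphenyl; in this assay compound 2 gives 3070 nM. Among the measured compounds shown here, the only measured step, a 2.6-fold lower number from compound 1 to compound 2 (0.41 log units; beyond the scatter), therefore shows that moving the hydroxyl alone can shift the result, and it leaves compound 1 with the highest of the two numbers, that is, the weaker inhibition.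

Compound 3 `Oc1cccc(-c2cc(-c3ccccc3C(F)(F)F)cc(-c3cccc(O)c3)n2)c1` is a different kind of change: 2-(trifluoromethyl)phenyl in place of 3-fluorophenyl on an aromatic carbon. For the measured compounds named here, no measured step touches that position, so the step from compound 1 to compound 2 gives no guide to its direction or size. Without a bearing step, the expectation is that compound 3 stays near compound 1, with a step of a 1.0-fold higher number from compound 1 to compound 3 (0.01 log units; within the scatter) that may well lie within the scatter. Compound 3 is thus estimated at 8000 nM, with a likely range from 2500 nM to 25000 nM.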

Compound 3, half-maximal inhibitory concentration: 8150 nM
Compound 3: the middle estimate sits 1.0-fold (0.01 log units) below what was measured, within the range that was stated.
By their numbers in this assay, from the lowest: compound 2; then compounds 1 and 3 (each within the scatter of the next).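

In this assay, putting 2-(trifluoromethyl)phenyl in place of 3-fluorophenyl on this aromatic carbon, opposite the ring nitrogen, gives a 1.0-fold higher number from compound 1 to compound 3 (0.02 log units; within the scatter) and so does not separate the two groups. The entering group has 10 heavy atoms against 7 for the group it replaces, and it carries three fluorine atoms instead of one, yet the read-out stays within the scatter, so this position accepts at least this one exchange without a measurable change in inhibition. Nothing available here explains why the two groups read alike.

The compounds shown carry only these two fluorine-bearing phenyl groups at this position, so it remains open whether an amine, a carboxylic acid or a longer alkyl chain there would leave the number just as unchanged or would shift it. As far as these compounds go, it is also open whether moving a hydroxyl to give a 4-hydroxyphenyl group, the change that gave a 2.6-fold lower number from compound 1 to compound 2 (0.41 log units; beyond the scatter), would have a similar effect on a compound carrying 2-(trifluoromethyl)phenyl.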